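The source may report more compounds than this note shows. Statements on the series, on what has been measured and on what is new or still open speak of the compounds shown alone.

Working notes on a small cytotoxicity series. The first compound, compound 1, `COc1ccc(/C=C/Cc2ccc(O)c(OC)c2OC)cc1O`, is a diarylpropene carrying a free phenol and three methoxy groups. In a functional assay on KB cells (Homo sapiens) for cytotoxicity, read by fluorescence and sulforhodamine B assay (on this read-out lower numbers stand for stronger inhibition and higher numbers for weaker inhibition), compound 1 gives 42700 nM. The second compound, compound 2, `O=C1C=C[C@](O)(C/C=C/c2ccccc2)CC1`, exchanges one aromatic ring for a hydroxylated cyclohexenone, keeping the propenyl linker to an unsubstituted phenyl ring. In this assay compound 2 gives 83700 nM. Of the two numbers shown, compound 2 and compound 1 lie within the usual scatter of each other, so the two cannot be told apart, and no step between them is worth recording.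

The next compound, compound 3, `COc1ccccc1/C=C/C[C@@]1(O)C=CC(=O)CC1`, keeps the core of compound 2 unchanged. The change is methoxy in place of hydrogen on an aromatic carbon. Going by the values given here, no measured pair isolates this kind of change, so there is nothing to calibrate it against. In this assay the step is expected to be a 1.2-fold lower number from compound 2 to compound 3 (0.08 log units; within the scatter), that is, none beyond the scatter. Compound 3 is therefore estimated at 70000 nM, with a range from 25000 nM to 200000 nM.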

Compound 3, half-maximal inhibitory concentration: 70900 nM
Compound 3: the middle estimate sits 1.0-fold (0.01 log units) below what was measured; the range from low to high includes it.
By their numbers in this assay, from the lowest: compounds 1, 3 and 2 (each within the scatter of the next).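

Going by these compounds alone, with a single methoxy in place of hydrogen on an aromatic carbon, ortho to a large group, this assay gives a 1.2-fold lower number from compound 2 to compound 3 (0.07 log units; within the scatter), the first step that changes one place only. At this position, the entry of methoxy, with its 2 heavy atoms and 1 hydrogen-bond acceptor, therefore moves the number no further than the scatter, and hydrogen and methoxy cannot be told apart here on this ring of the shared core. No measurement available here bears on the reason for this result.

This single step says nothing about whether another group on the same carbon, such as an amine, a carboxylic acid or a longer alkoxy chain, would move the number beyond the scatter. Also open, on these data alone, is whether methoxy on another carbon of this ring, or a second methoxy added to compound 3, would stay equally close, and whether the same holds with the other parts of the core changed.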